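A Hexyl Chain Replaces Hydroxyethyl on the Triazole

The source may hold more compounds than are shown below. What is called first, only, known or untested is meant among the compounds shown, and "the series" means these compounds.

Three compounds share one core and one read-out. In a functional assay on HepG2 cells (Homo sapiens) for inhibition, read by MTT assay, with a stated time of 72 h (on this read-out lower numbers stand for stronger inhibition and higher numbers for weaker inhibition), compound 1 `O=c1cc(Cn2cc(C3CC3)nn2)c2ccc(O)cc2o1` reaches only the limit of the assay, > 100000 nM. Compound 2 `CC(O)c1cn(Cc2cc(=O)oc3cc(O)ccc23)nn1` likewise gives a limit in this assay, > 100000 nM. Compound 3 `O=c1cc(Cn2cc(CCCO)nn2)c2ccc(O)cc2o1` also stops at a limit, > 100000 nM. Because of the limit of > 100000 nM in this assay, at which 3 of the 3 values shown sit, none of the steps between them can be read: a step that the two limits leave unreadable from compound 1 to compound 2, a step that the two limits leave unreadable from compound 1 to compound 3 and a step that the two limits leave unreadable from compound 2 to compound 3. Compound 4 `CCCCCCc1cn(Cc2cc(=O)oc3cc(O)ccc23)nn1` has not been measured; it differs from compound 2 by hexyl in place of 1-hydroxyethyl on an aromatic carbon. Going by the values given here, no measured step bears on this change in a readable way, so the expectation rests on the three limits alone. Compound 4 is expected to give about 80000 nM, within 15000 nM to 400000 nM. The expected step of an at least 1.2-fold lower number from compound 2 to compound 4 (0.09 log units; that floor lies within the scatter) is therefore uncertain in both size and direction.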

Compound 4, half-maximal inhibitory concentration: 61600 nM
Beside the measured number, compound 4's estimate is 1.3-fold (0.11 log units) above it; low and high end bracket the measured number.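

Going by these compounds alone, compound 4, whose hexyl group carries no hydrogen-bond donor or acceptor, is the only one of the four compounds to give a number inside the range of this assay. Against the others, this gives an at least 1.6-fold lower number from compound 2 to compound 4 (0.21 log units; that floor lies within the scatter), an at least 1.6-fold lower number from compound 3 to compound 4 (0.21 log units; that floor lies within the scatter) and an at least 1.6-fold lower number from compound 1 to compound 4 (0.21 log units; that floor lies within the scatter). These are only floors, and the true size of each step stays unknown because each starts from a limit: the limit of > 100000 nM in this assay, at which 3 of the 4 values shown sit.

On these data alone, whether a longer chain such as octyl would change the number remains open. So does the effect of an amine at the end of the hexyl chain.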